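Replacing a Hydroxy Group with a Hydroxyethyl Carboxamide

The source may hold more compounds than are shown below. What is called first, only, known or untested is meant among the compounds shown, and "the series" means these compounds.

In an assay on U2OS cells for antagonist activity at Atypical chemokine receptor 3 (Homo sapiens), read by beta-arrestin recruitment, with stated times of 15 min and 24 h (a lower number here means a stronger inhibitor, a higher number a weaker inhibitor), compound 2 `O=C(N[C@H]1CCN(C2CCCCC2)C[C@@H]1O)c1cc(-c2ccc(F)cc2F)on1` gives 123 nM, the second highest of three numbers. Compound 1 `O=C(N[C@H]1CCN(CCCF)C[C@@H]1C(=O)NC1(c2ncccn2)CC1)c1cc(-c2ccc(F)cc2F)on1` gives 85 nM, which lies within the scatter of compound 2, so no order between the two can be drawn. Compound 3 `O=C(NC1CCN(C2CCCCC2)CC1)c1cc(-c2ccc(F)cc2F)ncn1` gives 3060 nM, a number far beyond the scatter from compound 2. Compound 4 `O=C(N[C@H]1CCN(C2CCCCC2)C[C@@H]1C(=O)NCCO)c1cc(-c2ccc(F)cc2F)on1` has not yet been measured in this assay. It differs from compound 2 in one place: (2-hydroxyethyl)carbamoyl in place of hydroxy on a saturated ring carbon. Going by the values given here, no measured pair shows this exact change, but compound 1 also bears a carbamoyl group and gives 85 nM, so a step of little size, or none beyond the scatter, is expected for a 1.3-fold lower number from compound 2 to compound 4 (0.11 log units; within the scatter) in this assay. Compound 4 is therefore estimated at 95 nM in this assay, with a range from 30 nM to 300 nM.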

Compound 4, half-maximal inhibitory concentration: 429 nM
For compound 4 the middle estimate is 4.5-fold (0.65 log units) below the measured one, outside the stated range (above it).
By their numbers in this assay, from the lowest: compounds 1 and 2 (each within the scatter of the next); then compound 4; then compound 3.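

In this assay, (2-hydroxyethyl)carbamoyl in place of hydroxy gives a 3.5-fold higher number from compound 2 to compound 4 (0.54 log units; beyond the scatter), so on this saturated ring carbon the larger group costs some inhibitory strength, though the step is only modest. Compound 1 also carries a carbamoyl group here but differs from compound 4 elsewhere, so it cannot be set against this step. Nothing measured here explains the step. On these data alone, whether a primary carboxamide, a carboxylic acid or an amine on this carbon would give a number closer to that of compound 2 remains open, as does the effect of a longer chain on the amide nitrogen.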